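Pyridin-2-yl in place of 4-fluorophenyl on the chalcone chain

This account rests on a few compounds, and the source may have more. Where it says the series, first, only, none or still open, it means among the compounds named here.

The series shares the core of compound 1 `COc1ccc(C(=O)/C=C/c2ccc(F)cc2)c2c1C=CC(C)(C)O2` and varies only the aryl group on the double-bonded chain. In a functional assay on HCT-116 cells (Homo sapiens) for antiproliferative activity, read by MTT assay, with a stated time of 24 h (on this read-out lower numbers stand for stronger inhibition and higher numbers for weaker inhibition), compound 1 gives > 10000 nM, which is a limit of the assay rather than a number. Compound 2 `COc1ccc(C(=O)/C=C/c2ccc3ccccc3n2)c2c1C=CC(C)(C)O2`, carrying quinolin-2-yl, gives 4530 nM in this assay. Thus compound 1 sits at the weak end of the values shown, and the only numbered value belongs to compound 2; no single step between the two measured compounds is defined, so their values are simply reported side by side, and the limit of > 10000 nM in this assay, at which 1 of the 2 values shown sits, marks where compound 1 stands.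

Compound 3 `COc1ccc(C(=O)/C=C/c2ccccn2)c2c1C=CC(C)(C)O2` is not yet measured. It differs from compound 1 as follows: pyridin-2-yl in place of 4-fluorophenyl on a double-bonded chain carbon bound to a double-bonded chain carbon. Within the data shown here, no measured step covers this change. Compound 3 is expected to show a step from compound 1 of an at least 1.2-fold lower number from compound 1 to compound 3 (0.09 log units; that floor lies within the scatter), a modest move toward stronger inhibition that may not exceed the scatter. In this assay compound 3 is therefore estimated at 8000 nM, within a range from 3000 nM to 30000 nM.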

Compound 3, half-maximal inhibitory concentration: 6630 nM
For compound 3 the middle estimate is 1.2-fold (0.08 log units) above the measured one, and the stated range covers the measured number.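

The change to pyridin-2-yl on a double-bonded chain carbon bound to a double-bonded chain carbon reads in this assay as an at least 1.5-fold lower number from compound 1 to compound 3 (0.17 log units; that floor lies within the scatter). Going by these compounds, this step is only a floor, because compound 1 stands at a limit of the assay and not at a number: the limit of > 10000 nM in this assay, at which 1 of the 3 values shown sits. What the result adds is that a single six-membered aromatic ring with 1 hetero atom at this place gives a numbered value, whereas 4-fluorophenyl on the same core gives only a limit, so the true size of the step remains unknown and may be larger than its floor.

The change swaps two things at once, removing the fluorine and bringing a nitrogen into the ring, and the compounds shown do not separate the two, so it stays open whether plain phenyl would read like compound 1 or like compound 3. On these data alone, it also stays open how pyridin-3-yl, pyridin-4-yl or thiophen-2-yl on the same chain carbon would read in this assay, and with them whether the place of the ring nitrogen matters at all.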